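The compounds below may be only part of what the source reports. "The series", "measured", "known", "first", "only" and "open" are said of these compounds alone.

Compound 1, `C=CCOc1c(Br)cc(Br)cc1Oc1ccc(Br)cc1Br`: 27.9 ug/mL
Compound 2, `Brc1ccc(Oc2cc(Br)cc(Br)c2OCc2ccccc2)c(Br)c1`: 27.9 ug/mL
Compound 3, `CC(C)(C)C(=O)C(C#N)Oc1c(Br)cc(Br)cc1Oc1ccc(Br)cc1Br`: 29.2 ug/mL

All three compounds were tested in a functional assay on HL-60 cells (Homo sapiens) for cytotoxicity, read by MTT assay, with a stated time of 24 h; on this read-out higher numbers stand for weaker inhibition and lower numbers for stronger inhibition. Each carries a different group on the same oxygen of the shared core, and the three numbers sit close together: the step of a 1.0-fold higher number from compound 1 to compound 3 (0.02 log units; within the scatter) and the step of a 1.0-fold higher number from compound 2 to compound 3 (0.02 log units; within the scatter) are both within the scatter, as is no change at the digits printed from compound 1 to compound 2 (within the scatter). Compound 3 therefore stands among the other two rather than apart from them; its number cannot be told from theirs on the strength of this assay.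

Compound 4, `BrCCOc1c(Br)cc(Br)cc1Oc1ccc(Br)cc1Br`, is the next compound in this series and has not yet been measured. It differs from compound 3 at the same oxygen: 2-bromoethyl in place of cyano((tert-butyl)carbonyl)methyl on an oxygen on an aromatic ring. For the measured compounds named here, the steps that bear on this change are the three already seen, each of which swapped the group on this oxygen and each of which left the number unchanged within the scatter. On that basis the step of a 1.0-fold lower number from compound 3 to compound 4 (0.02 log units; within the scatter) is expected to be no larger than the scatter in this assay. Compound 4 is accordingly estimated at 28 ug/mL, with a range from 14 ug/mL to 56 ug/mL.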

Compound 4, half-maximal inhibitory concentration: 26.2 ug/mL
Estimate against measurement, compound 4: 1.1-fold (0.03 log units) above, within the range that was stated.
By their numbers in this assay, from the lowest: compounds 4, 1, 2 and 3 (each within the scatter of the next).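

In this assay, 2-bromoethyl takes the place of cyano((tert-butyl)carbonyl)methyl on the oxygen, a swap from 9 heavy atoms to 3 heavy atoms and from 2 hydrogen-bond acceptors to 0, yet the step stays within the scatter (a 1.1-fold lower number from compound 3 to compound 4 (0.05 log units; within the scatter)). The same holds when this bromine-bearing chain is set against the benzyl and allyl groups (a 1.1-fold lower number from compound 2 to compound 4 (0.03 log units; within the scatter)) (a 1.1-fold lower number from compound 1 to compound 4 (0.03 log units; within the scatter)), so four groups that differ this much in size and make-up, now including one with a bromine atom, cannot be told apart in this assay. No measurement shown here offers a reason for this flat picture.

The compounds shown leave open whether any group on this oxygen can shift the number at all: an amine or a carboxylic acid at the end of the chain, or a much longer alkyl chain, might do so or might not. As far as these compounds go, whether the shared core alone sets the level seen in this assay also stays open, and all four compounds carry that same core.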